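This account rests on a few compounds, and the source may have more. Where it says the series, first, only, none or still open, it means among the compounds named here.

Measured compounds:
- compound 1, `CCn1nc(-c2ccnc(Nc3cccc(S(N)(=O)=O)c3)n2)c2ccccc21`: 9010 nM
- compound 2, `CCn1nc(-c2ccnc(Nc3ccc([N+](=O)[O-])cc3)n2)c2ccccc21`: 4060 nM
- compound 3, `CCn1nc(-c2ccnc(Nc3cccc([N+](=O)[O-])c3)n2)c2ccccc21`: 2820 nM

All three share one core and differ only in the group on the outer ring. In a functional assay on HCT-116 cells (Homo sapiens) for antiproliferative activity, read by MTT assay, with a stated time of 72 h (a higher number here means a weaker inhibitor of growth, a lower number a stronger inhibitor of growth), compound 3 gives the lowest of the three numbers. Its gap to compound 2 is within the scatter, so the two cannot be ranked; its gap to compound 1 is beyond it, as the step of a 3.2-fold lower number from compound 1 to compound 3 (0.50 log units; beyond the scatter) shows. The step of a 1.4-fold lower number from compound 2 to compound 3 (0.16 log units; within the scatter) shows that moving the nitro group around the ring changed little.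

Compound 4, `CCn1nc(-c2ccnc(Nc3cccc(O)c3)n2)c2ccccc21`, carries the change (hydroxy in place of nitro on an aromatic carbon). Among the measured compounds shown here, only the step from compound 1 to compound 3 bears on it, since it is the only one that swaps the group itself rather than its place, and it was modest. For the measured compounds named here, no measured compound carries a hydroxy group, so the direction is uncertain; a modest rise in the number is expected, a 1.8-fold higher number from compound 3 to compound 4 (0.25 log units; within the scatter). Compound 4 is estimated at 5000 nM, between 1800 nM and 15000 nM.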

Compound 4, concentration for 50% growth inhibition: 36600 nM
Compound 4: the middle estimate sits 7.3-fold (0.86 log units) below what was measured; measured number outside the range, above it.
By their numbers in this assay, from the lowest: compounds 3 and 2 (each within the scatter of the next); then compound 1; then compound 4.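

In this assay, among the compounds shown here, the group on this aromatic carbon turns out to matter far more than the earlier compounds suggested: replacing nitro with hydroxy gives a 13-fold higher number from compound 3 to compound 4 (1.11 log units; beyond the scatter), a large step, whereas the earlier swap of sulfamoyl for nitro was only modest. The hydroxy compound also stands apart from the sulfamoyl compound, with a 4.1-fold higher number from compound 1 to compound 4 (0.61 log units; beyond the scatter), so its number exceeds those of both other groups tried at this place. The comparison with the other nitro isomer gives a 9.0-fold higher number from compound 2 to compound 4 (0.95 log units; beyond the scatter), so the rise does not depend on which nitro compound serves as the reference.

No measurement here explains why hydroxy behaves this way. From the compounds shown here alone, it remains open whether an amine or a methoxy group on this carbon would give a number nearer that of hydroxy or that of nitro.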